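The compounds below may be only part of what the source reports. "The series", "measured", "known", "first", "only" and "open" are said of these compounds alone.

In a functional assay on MCF7 cells (Homo sapiens) for antiproliferative activity (on this read-out lower numbers stand for stronger inhibition and higher numbers for weaker inhibition), three compounds have been measured. Compound 1 `CC(=O)Oc1ccc(C(=O)Nc2cc3ccc(OCC4CCCN(C)C4)c(C)c3oc2=O)cc1CC=C(C)C` gives 1650 nM, compound 2 `CC(=O)Oc1ccc(C(=O)Nc2cc3ccc(OCC4CCCNC4)c(C)c3oc2=O)cc1CC=C(C)C` gives 820 nM and compound 3 `CC(C)=CCc1cc(C(=O)Nc2cc3ccc(OCC4CCN(C)C4)c(C)c3oc2=O)ccc1O` gives 1550 nM. Compound 3 lies within the scatter of both others, so the three numbers are not separated. Compound 1 and compound 2 also differ from compound 3 outside the amine side chain.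

Compound 4 `CCCNCCCOc1ccc2cc(NC(=O)c3ccc(O)c(CC=C(C)C)c3)c(=O)oc2c1C` differs from compound 3 by one change: 2-(propylamino)ethyl in place of 1-methylpyrrolidin-3-yl on a saturated chain carbon bound to an oxygen on an aromatic ring. In words, 2-(propylamino)ethyl stands in place of 1-methylpyrrolidin-3-yl on a saturated chain carbon bound to an oxygen on an aromatic ring.

Going by the values given here, the only measured step that bears on this is a 2.0-fold lower number from compound 1 to compound 2 (0.30 log units; within the scatter), with hydrogen in place of methyl on an amine nitrogen in a ring. Among the compounds with values here, it stays within the scatter and touches only part of the change, and no measured step removes the ring. No step beyond the scatter is therefore expected in this assay. The expected step is a 1.3-fold lower number from compound 3 to compound 4 (0.11 log units; within the scatter). For compound 4 the estimate is 1200 nM, with an expected range from 500 nM to 3000 nM.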

Compound 4, half-maximal inhibitory concentration: 980 nM
The estimate for compound 4 lay 1.2-fold (0.09 log units) above the measured number; the range from low to high includes it.
By their numbers in this assay, from the lowest: compounds 2, 4, 3 and 1 (each within the scatter of the next).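

In this assay, removing the ring on a saturated chain carbon bound to an oxygen on an aromatic ring gives a 1.6-fold lower number from compound 3 to compound 4 (0.20 log units; within the scatter), so 2-(propylamino)ethyl can stand in place of 1-methylpyrrolidin-3-yl without a step beyond the scatter. The earlier step changed only the substituent on a ring nitrogen, whereas this one shows that neither the intact ring nor the absence of a hydrogen-bond donor in this group is needed to stay within the scatter. No measured evidence on the compounds bears on this result.

From the compounds shown here alone, it remains open whether a carboxylic acid, or a butyl chain with no nitrogen, at this place would give a step beyond the scatter. Going by these compounds, it is also open whether the ring-to-chain change reads the same with the acetate of compound 1 in place of the hydroxyl of compound 4.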